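The compounds below may be only part of what the source reports. "The series", "measured", "known", "first", "only" and "open" are said of these compounds alone.

Compound 3 `O=C(NC1CCN(Cc2ccccc2)CC1)c1coc2ccc(OCc3ccccc3)cc2c1=O` gives the lowest number of the three measured compounds in an assay on isolated protein for inhibition of Amine oxidase [flavin-containing] B (Homo sapiens), read by fluorescence and Amplex Red, with stated times of 15 min and 20 min (on this read-out lower numbers stand for stronger inhibition and higher numbers for weaker inhibition), namely 35 nM. Compound 1 `O=C(NC1CCN(Cc2ccccc2)CC1)c1coc2ccccc2c1=O` gives 17700 nM in this assay, and compound 2 `COc1ccc2occ(C(=O)NC3CCN(Cc4ccccc4)CC3)c(=O)c2c1` gives 46300 nM. Compound 4 `O=C(NC1CCN(Cc2ccccc2)CC1)c1coc2ccc(Br)cc2c1=O` differs from compound 3 by bromo in place of benzyloxy on an aromatic carbon. Going by the values given here, two measured steps bear on this change: benzyloxy entering in place of hydrogen gave a 510-fold lower number from compound 1 to compound 3 (2.70 log units; beyond the scatter), and phenyl entering on the chain carbon gave a 1300-fold lower number from compound 2 to compound 3 (3.12 log units; beyond the scatter). Both point to the benzyloxy group as what sets compound 3 apart. Nothing measured here tells what bromo alone contributes at that position. Compound 4 is therefore expected to show a large rise, estimated as a 140-fold higher number from compound 3 to compound 4 (2.15 log units; beyond the scatter). Compound 4 is thus expected to give about 5000 nM, within a range from 800 nM to 30000 nM.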

Compound 4, half-maximal inhibitory concentration: 22800 nM
Beside the measured number, compound 4's estimate is 4.6-fold (0.66 log units) below it; the measured number falls inside the stated range.
By their numbers in this assay, from the lowest: compound 3; then compounds 1 and 4 (each within the scatter of the next); then compound 2.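

In this assay bromo in place of benzyloxy gives a 650-fold higher number from compound 3 to compound 4 (2.81 log units; beyond the scatter) and does not keep the low number of compound 3. Bromo in place of hydrogen gives a 1.3-fold higher number from compound 1 to compound 4 (0.11 log units; within the scatter) so the two cannot be told apart here, and bromo in place of methoxy gives only a 2.0-fold lower number from compound 2 to compound 4 (0.31 log units; beyond the scatter) so at this position the low number goes with benzyloxy, not with substitution as such. No evidence on why this is so is available.
Open, as far as these compounds go, is whether a longer chain ending in phenyl, or an amine in place of the benzyloxy oxygen, would keep that low number.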